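The source may hold more compounds than are shown below. What is called first, only, known or untested is meant among the compounds shown, and "the series" means these compounds.

Three members of this series have been measured in a functional assay on A549 cells (Homo sapiens) for inhibition, read by sulforhodamine B assay, tested at 10 uM; a lower number here means less inhibition of growth, a higher number more inhibition of growth at the concentration tested. Compound 1 `CC(=O)N1N=C(c2ccc(OCc3cn(Cc4ccc([N+](=O)[O-])cc4)nn3)cc2)CC1c1ccccc1` gives 15% in this assay. Within the data shown here, compound 2 `COc1ccc(C2CC(c3ccc(OCc4cn(Cc5ccc([N+](=O)[O-])cc5)nn4)cc3)=NN2C(C)=O)cc1` gives 26% in this assay, and the single one-place step between them, a number 11 percentage points higher from compound 1 to compound 2 (beyond the scatter), is methoxy in place of hydrogen on an aromatic carbon. Compound 3 `COc1cc(C2CC(c3ccc(Br)cc3)=NN2C(C)=O)ccc1OCc1cn(Cc2ccc([N+](=O)[O-])cc2)nn1` gives 0% in this assay, the lowest of the three numbers: compound 1 lies nearest to it and compound 2 furthest, and both gaps are beyond the scatter.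

Compound 4 `COc1ccc(C2=NN(C(C)=O)C(c3ccc(OCc4cn(Cc5ccc([N+](=O)[O-])cc5)nn4)c(OC)c3)C2)cc1` is not yet measured. It differs from compound 3 in one place: methoxy in place of bromo on an aromatic carbon. Among the measured compounds shown here, no measured step swaps bromo for methoxy, so the only guidance is the step from compound 1 to compound 2, where adding a methoxy group raised the number modestly. That step concerns a different starting group, so it bears on the present change only loosely. Still, because compound 2 reaches 26% while compound 3 sits at 0%, a small upward move is the expectation rather than a fall.

Compound 4 is therefore expected to reach about 10% in this assay, within a range from 0% to 25%, which would mean an estimated step of a number 10 percentage points higher from compound 3 to compound 4 (within the scatter).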

Compound 4, percent growth inhibition at one concentration: 43%
Estimate against measurement, compound 4: 33 percentage points below; the whole stated range lies below it.
By their numbers in this assay, from the lowest: compound 3; then compound 1; then compound 2; then compound 4.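

In this assay, the change from 4-bromophenyl to 4-methoxyphenyl gives a large gain, a number 43 percentage points higher from compound 3 to compound 4 (beyond the scatter), lifting a compound that showed no growth inhibition at the concentration tested, as compound 3 at 0% does, to the highest number in the set, with compound 4 at 43%. The earlier methoxy step, a number 11 percentage points higher from compound 1 to compound 2 (beyond the scatter), replaced a hydrogen, whereas this one replaces a bromine, so the result shows that the group on this ring, para to a large group, can matter a great deal for this read-out, and that a swap of one heavy atom for two can carry that much weight. No measurement offered here accounts for the size of this step.

From the compounds shown here alone, what stays open is whether the gain comes from losing the bromine or from gaining the methoxy group, a question that a plain hydrogen, a chlorine or a hydroxyl group at this same position would help to settle. Going by these compounds, it is also open whether a longer chain such as ethoxy, or an amine in the same place, would keep, raise or lose the effect.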